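From Furan-2-yl to Pyridin-4-yl on a Carbonyl Carbon

The compounds below may be only part of what the source reports. "The series", "measured", "known", "first", "only" and "open" are said of these compounds alone.

For the measured compounds named here, only two compounds have numbers so far. In a functional assay on KB cells (Homo sapiens) for cytotoxicity (a lower number here means a stronger inhibitor, a higher number a weaker inhibitor), compound 1 (`COc1ccc(S(=O)(=O)N2CCc3cccc(NC(=O)c4ccncc4)c32)cc1`) gives 9.6 nM, and compound 2 (`COc1ccc(S(=O)(=O)N2CCc3cc(Br)cc(NC(=O)c4ccco4)c32)cc1`) gives 89 nM. Compound 2 therefore holds the higher of the two numbers, and its gap to compound 1 lies beyond the scatter.

Compound 3 (`COc1ccc(S(=O)(=O)N2CCc3cc(Br)cc(NC(=O)c4ccncc4)c32)cc1`) has not yet been measured. It carries pyridin-4-yl in place of the furan-2-yl of compound 2, on a carbonyl carbon: pyridin-4-yl in place of furan-2-yl on a carbonyl carbon. Going by the values given here, no measured pair shows this change alone, so its size remains uncertain. Compound 1 also carries pyridin-4-yl on its carbonyl carbon and stands at 9.6 nM, so a lower number in this assay, beyond the scatter, is expected. The expected change is a 3.0-fold lower number from compound 2 to compound 3 (0.47 log units; beyond the scatter). For compound 3, the estimated value is 30 nM, with an expected range from 8 nM to 110 nM.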

Compound 3, half-maximal inhibitory concentration: 91 nM
Compound 3: middle estimate off by 3.0-fold (0.48 log units), on the low side; the range from low to high includes it.
By their numbers in this assay, from the lowest: compound 1; then compounds 2 and 3 (each within the scatter of the next).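

With the bromo group held in place in this assay, exchanging furan-2-yl for pyridin-4-yl on the carbonyl carbon leaves the result within the scatter (a 1.0-fold higher number from compound 2 to compound 3 (0.01 log units; within the scatter)), so the two rings cannot be told apart at this position in this setting. The one bromo step shown, bromo in place of hydrogen on an aromatic carbon, is instead beyond the scatter (a 9.5-fold higher number from compound 1 to compound 3 (0.98 log units; beyond the scatter)), and it gives the first reading of that change alone. Nothing available offers an explanation for either result.

Going by these compounds, whether furan-2-yl and pyridin-4-yl would also stay within the scatter of each other with hydrogen in place of bromo remains open. So does how a methyl group, a chloro group or an amine on that aromatic carbon would compare with bromo and hydrogen.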